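Acylation of the amine: from formyl to acetyl

The compounds below may be only part of what the source reports. "The series", "measured", "known", "first", "only" and "open" are said of these compounds alone.

Measured so far:
compound 1, `Cc1nc2c(OCc3ccccc3)cccn2c1N`: 97%
compound 2, `Cc1nc2c(NCc3ccccc3)cccn2c1N`: 98%
compound 3, `Cc1nc2c(OCc3ccccc3)cccn2c1NC=O`: 3%

In a functional assay on the whole organism with Canis familiaris (Canis lupus familiaris) as the target, at a dose of 2 mg/kg by the intravenous route (a higher number here means a stronger effect of the compound at the dose given, a lower number a weaker effect), compound 3 stands lowest of the three, far beneath compound 1 and compound 2. Among the measured compounds shown here, the only step touching it, a number 94 percentage points lower from compound 1 to compound 3 (beyond the scatter), shows how strongly the formyl group on the ring nitrogen cut the effect. Compound 4, `CC(=O)Nc1c(C)nc2c(OCc3ccccc3)cccn12`, keeps that acyl group and only enlarges it: methyl in place of hydrogen on a carbonyl carbon. For the measured compounds named here, no measured step tells what a larger acyl group does, but the one step that exists points to acylated compounds giving little. Compound 4 is therefore expected to stay near compound 3, with a step of a number 3 percentage points higher from compound 3 to compound 4 (within the scatter) within the scatter, and is estimated at 6%, between 0% and 25%.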

Compound 4, a percentage reported as inhibition, in the whole organism at one dose (the size of the read-out at that dose, not a potency): 24%
Beside the measured number, compound 4's estimate is 18 percentage points below it; low and high end bracket the measured number.
By their numbers in this assay, from the lowest: compound 3; then compound 4; then compounds 1 and 2 (each within the scatter of the next).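

In this assay, acylating the nitrogen on the aromatic ring does not fix the result at one low level, since methyl in place of hydrogen on a carbonyl carbon gives a modest gain (a number 21 percentage points higher from compound 3 to compound 4 (beyond the scatter)). Acetyl still leaves most of the effect lost compared with the hydrogen it replaces (a number 73 percentage points lower from compound 1 to compound 4 (beyond the scatter)). No measured evidence here explains why the added methyl changes the number. As far as these compounds go, with only formyl and acetyl, it remains open whether a longer chain such as propionyl would raise the number further. From the compounds shown here alone, the same acetyl change on compound 2 also remains untested here.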